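This account rests on a few compounds, and the source may have more. Where it says the series, first, only, none or still open, it means among the compounds named here.

Measured compounds:
compound 1, `CS(=O)(=O)c1ccc(-c2cnc3[nH]cc(-c4nnc(-c5ccccc5)o4)c(=O)c3c2)cc1`, with 27.2%
compound 2, `N#Cc1ccc(-c2cnc3[nH]cc(-c4nnc(-c5ccc(Cl)cc5)o4)c(=O)c3c2)cc1`, with 35.4%

In a functional assay on HCT-116 cells (Homo sapiens) for positive allosteric modulation, read by MTT assay, with stated times of 24 h and 48 h, tested at 2.5 uM (on this read-out lower numbers stand for less inhibition of growth and higher numbers for more inhibition of growth at the one concentration tested), compound 1 gives 27.2%, while compound 2 gives 35.4%; the two numbers lie within the scatter of each other, so neither compound stands apart from the other. Compound 3, `Cc1cccc(-c2nnc(-c3c[nH]c4ncc(-c5ccc(S(C)(=O)=O)cc5)cc4c3=O)o2)c1`, differs from compound 1 by methyl in place of hydrogen on an aromatic carbon. Going by the values given here, no measured pair in this set carries the same change, so nothing shows how it acts in this assay. The account therefore expects a number 2.8 percentage points higher from compound 1 to compound 3 (within the scatter), a step in no direction beyond the scatter. Compound 3 is estimated at 30% in this assay, within a range from 15% to 46%.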

Compound 3, percent growth inhibition at one concentration: 50.8%
Compound 3: the middle estimate sits 20.8 percentage points below what was measured; measured number above the stated range.
By their numbers in this assay, from the lowest: compounds 1 and 2 (each within the scatter of the next); then compound 3.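

In this assay the change from phenyl to 3-methylphenyl gives a number 23.6 percentage points higher from compound 1 to compound 3 (beyond the scatter), so this place on the ring, meta to a large group, responds to the addition of a single methyl. The earlier compounds shown here showed no step that could be read at this position. Nothing available explains this step. From the compounds shown here alone, whether an amine or a methoxy group at this place would act the same way remains open. So does whether methyl on another carbon of this ring would give a similar step.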